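The source may hold more compounds than are shown below. What is called first, only, known or untested is meant among the compounds shown, and "the series" means these compounds.

Series so far, all read in a functional assay on RAW264.7 cells (Mus musculus) for inhibition, read by Griess assay, with stated times of 3 h and 24 h; a higher number here means a weaker inhibitor, a lower number a stronger inhibitor:

- compound 1 `C=C1CCC2C(C)(CO)[C@H](O)CC[C@@]2(C)[C@@H]1CCn1c(N)nccc1=O`: > 100000 nM
- compound 2 `C=C1CCC2[C@](C)(CO)[C@H](O)CC[C@@]2(C)[C@@H]1CCOc1cccc2ccccc12`: 44700 nM
- compound 3 `C=C1CCC2[C@](C)(CO)[C@H](O)CC[C@@]2(C)[C@@H]1CCOc1ccc(Oc2ccccc2)cc1`: 12800 nM

Compound 1 gives only a limit of the assay, > 100000 nM. Compound 3, at 12800 nM, has the lowest of the two true numbers. Compound 2, at 44700 nM, lies higher by more than the scatter.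

Next is compound 4 `C=C1CCC2[C@](C)(CO)[C@H](O)CC[C@@]2(C)[C@@H]1CCOc1ccc(C(C)(C)C)cc1`, with tert-butyl in place of phenoxy on an aromatic carbon. For the measured compounds named here, no two measured compounds differ in one place only, which leaves this change without a direct precedent. Compound 4 keeps the shared core and the six-membered aromatic ring of compound 3 at 12800 nM, so a number near that of compound 3 is the working expectation. In this assay a small move towards a higher number is expected, probably not beyond the scatter. The expected step is a 1.4-fold higher number from compound 3 to compound 4 (0.15 log units; within the scatter). For compound 4 the estimated value is 18000 nM, with an expected range of 6000 nM to 55000 nM.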

Compound 4, half-maximal inhibitory concentration: 35800 nM
The estimate for compound 4 lay 2.0-fold (0.30 log units) below the measured number, within the range that was stated.
By their numbers in this assay, from the lowest: compound 3; then compounds 4 and 2 (each within the scatter of the next). At a limit, above all of these: compound 1.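

In this assay, the series gains its first comparison of compounds that differ in one place: tert-butyl in place of phenoxy on an aromatic carbon, para to a large group, gives a 2.8-fold higher number from compound 3 to compound 4 (0.45 log units; beyond the scatter). This position is therefore not indifferent to the group it carries, and of these two groups, phenoxy goes with the lower number. The data at hand give no measured property that accounts for this step.

One pair cannot separate the part played by the aromatic ring of phenoxy from that of its oxygen, so the compounds shown leave open how each contributes. Also open, as far as these compounds go, is how this position would respond to a phenyl group, which keeps the ring without the oxygen, or to an amine or a carboxylic acid.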